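Shortening the nitrile tether on the shared core

This account rests on a few compounds, and the source may have more. Where it says the series, first, only, none or still open, it means among the compounds named here.

Of the compounds shown here, three built on one core have been measured in a functional assay on H4 cells for agonist activity at growth hormone secretagogue receptor type 1 (Homo sapiens), read by FLIPR; on this read-out lower numbers stand for an effect already at smaller amounts and higher numbers for an effect only at larger amounts of compound. Compound 1 `CC(C)(N)C(=O)N[C@H](COCc1ccccc1)c1nnnn1Cc1ccc(NS(C)(=O)=O)cc1` gives 259 nM. Compound 2 `CC(C)(N)C(=O)N[C@H](COCc1ccccc1)c1nnnn1CCCc1ccccc1` gives 17 nM, and compound 3 `CC(C)(N)C(=O)N[C@H](COCc1ccccc1)c1nnnn1CCCCC#N` gives 35 nM. The steps between them are as follows: a 15-fold lower number from compound 1 to compound 2 (1.18 log units; beyond the scatter); a 7.4-fold lower number from compound 1 to compound 3 (0.87 log units; beyond the scatter); a 2.1-fold higher number from compound 2 to compound 3 (0.31 log units; beyond the scatter). Compound 3 therefore stands second highest of the three numbers, closer to compound 2 than to compound 1.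

Compound 4 `CC(C)(N)C(=O)N[C@H](COCc1ccccc1)c1nnnn1CCC#N` differs from compound 3 only by cyano in place of 2-cyanoethyl on a saturated chain carbon, two bonds along the chain from an aromatic nitrogen. Among the measured compounds shown here, no measured pair repeats this shortening of the chain at this position. The step that bears most on it is a 2.1-fold higher number from compound 2 to compound 3 (0.31 log units; beyond the scatter), which exchanged the group three bonds along the chain and moved the number only modestly. The larger steps of a 15-fold lower number from compound 1 to compound 2 (1.18 log units; beyond the scatter) and a 7.4-fold lower number from compound 1 to compound 3 (0.87 log units; beyond the scatter) concern the removal of an aryl group sitting directly on the chain carbon and speak less directly to a change in chain length. For the measured compounds named here, on this basis the account expects only a modest movement in this assay, most likely toward a higher number, because the closest precedent a 2.1-fold higher number from compound 2 to compound 3 (0.31 log units; beyond the scatter) was itself modest. This corresponds to an expected step of a 2.0-fold higher number from compound 3 to compound 4 (0.30 log units; within the scatter). Compound 4 is therefore estimated at 70 nM, with a range from 20 nM to 250 nM.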

Compound 4, half-maximal effective concentration: 30 nM
For compound 4 the middle estimate is 2.3-fold (0.37 log units) above the measured one; low and high end bracket the measured number.
By their numbers in this assay, from the lowest: compounds 2, 4 and 3 (each within the scatter of the next, the first and the last beyond it); then compound 1.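

In this assay, cyano in place of 2-cyanoethyl on a saturated chain carbon, two bonds along the chain from an aromatic nitrogen, gives a 1.2-fold lower number from compound 3 to compound 4 (0.07 log units; within the scatter), so the 4-cyanobutyl and 2-cyanoethyl chains cannot be told apart at this position. Cyano in place of benzyl at the same place gives a 1.8-fold higher number from compound 2 to compound 4 (0.25 log units; within the scatter), which also lies within the scatter, whereas compound 3 had stood just beyond the scatter of compound 2; the nitrile chain as such therefore does not set a clear gap from the phenyl-ended chain. The shortened chain also keeps the distance from the sulfonamide-bearing aryl compound, with an 8.6-fold lower number from compound 1 to compound 4 (0.94 log units; beyond the scatter) for cyanomethyl in place of 4-(methanesulfonamido)phenyl, so the shorter nitrile chain gives up none of what the longer one gained.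

The compounds shown leave open whether the nitrile is needed at all: a plain propyl chain, or an amine or a carboxylic acid at the chain end, would settle that. No measurement offered here accounts for why the length of the nitrile chain makes so little difference.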